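Thiosemicarbazones: phenyl to pyrrolyl on the hydrazone carbon

A few compounds are considered here, and "the series" means these few. Any claim that something is new, unique, unknown or untested is made for them only; others in the source may bear on it.

Compound 1 `CC1=CC[C@H](C(C)(C)NC(=S)N/N=C/c2ccccc2)CC1`: 1300 nM
Compound 2 `CC1=CC[C@H](C(C)(C)NC(=S)N/N=C/c2ccccc2Cl)CC1`: 50 nM
Compound 3 `CC1=CC[C@H](C(C)(C)NC(=S)N/N=C/c2ccc(Cl)cc2)CC1`: 50 nM

In a functional assay on PC-3 cells (Homo sapiens) for inhibition, read by sulforhodamine B assay, with a stated time of 48 h (on this read-out higher numbers stand for weaker inhibition of growth and lower numbers for stronger inhibition of growth), compound 1 gives the highest number of the three. The two measured steps both add a chloro substituent: a 26-fold lower number from compound 1 to compound 2 (1.41 log units; beyond the scatter) and a 26-fold lower number from compound 1 to compound 3 (1.41 log units; beyond the scatter), while the pair of chloro compounds shows no change at the digits printed from compound 2 to compound 3 (within the scatter). Compound 4 `CC1=CC[C@H](C(C)(C)NC(=S)N/N=C/c2ccc[nH]2)CC1` differs from compound 1 by 1H-pyrrol-2-yl in place of phenyl on a carbon with a double bond to nitrogen. Within the data shown here, no measured step bears on this change, since every measured step keeps the phenyl and alters only its substituents. The expectation therefore rests on compound 1 alone, and the estimated step is no change at the digits printed from compound 1 to compound 4 (within the scatter), with no direction supported beyond the scatter. Compound 4 is expected to give about 1300 nM, within a range from 300 nM to 5000 nM.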

Compound 4, concentration for 50% growth inhibition: 2800 nM
Beside the measured number, compound 4's estimate is 2.2-fold (0.33 log units) below it; low and high end bracket the measured number.
By their numbers in this assay, from the lowest: compounds 2 and 3 (each within the scatter of the next); then compound 1; then compound 4.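

Swapping the ring itself at this position, rather than only its substituent, moves the number the same way as removing chloro, though far less: a 2.2-fold higher number from compound 1 to compound 4 (0.33 log units; beyond the scatter) in this assay. The chloro compounds stand much further away, with a 56-fold higher number from compound 3 to compound 4 (1.75 log units; beyond the scatter) and a 56-fold higher number from compound 2 to compound 4 (1.75 log units; beyond the scatter), so 1H-pyrrol-2-yl in place of either chlorophenyl costs far more than in place of plain phenyl. No evidence is available to account for these steps. The compounds shown leave open whether chloro on the 1H-pyrrol-2-yl ring would lower the number as it does on phenyl, and how a pyridyl or furyl ring, or a dimethylamino group on the phenyl, would behave here.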